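A few compounds are considered here, and "the series" means these few. Any claim that something is new, unique, unknown or untested is made for them only; others in the source may bear on it.

Going by the values given here, compound 1 `COc1ccc2c(c1O)CCCC(c1cc(OC)c(OC)c(OC)c1)=C2` is one of two compounds measured in a functional assay on NCI-H460 cells (Homo sapiens) for inhibition, read by sulforhodamine B assay, with a stated time of 48 h; on this read-out lower numbers stand for stronger inhibition of growth and higher numbers for weaker inhibition of growth. There compound 1 gives 1200 nM, the higher of the two numbers, while compound 2 `COc1ccc2c(c1)CCCC=C2c1cc(OC)c(OC)c(OC)c1` gives 51 nM. Compound 3 `COc1ccc2c(c1)CCCC(c1cc(OC)c(OC)c(OC)c1)=C2` has not been measured; it differs from compound 1 by hydrogen in place of hydroxy on an aromatic carbon, on an aromatic carbon ortho to a methoxy group and to a fused ring. Among the compounds with values here, no measured pair shows this exact change, so the step is expected to be modest, toward a lower number and likely beyond the scatter, with a 4.8-fold lower number from compound 1 to compound 3 (0.68 log units; beyond the scatter) as the estimate. Compound 3 is expected to give 250 nM, between 60 nM and 900 nM.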

Compound 3, concentration for 50% growth inhibition: 470 nM
For compound 3 the middle estimate is 1.9-fold (0.27 log units) below the measured one; the range from low to high includes it.
By their numbers in this assay, from the lowest: compound 2; then compound 3; then compound 1.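

Going by these compounds alone, replacing the hydroxy with hydrogen on this aromatic carbon gives a 2.6-fold lower number from compound 1 to compound 3 (0.41 log units; beyond the scatter) in this assay and so provides the first direct reading of this position. The hydroxy is therefore not needed for growth inhibition in this pair, and the compound that carries it has the weaker effect. Nothing available explains the direction or size of this step.

Only hydroxy and hydrogen can be compared at this carbon. Going by these compounds, how an amine or a carboxylic acid would behave there remains open.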